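Removing a methyl twice: what a limit and a step suggest

This account rests on a few compounds, and the source may have more. Where it says the series, first, only, none or still open, it means among the compounds named here.

Compound 1, `CCCNc1nc2cc(-c3ccc(C)cc3)sc2c(=O)[nH]1`, reaches only a limit of > 62500 nM in an ADME assay on HepG2 cells (Homo sapiens) for cytotoxicity, read by MTT assay, with a stated time of 72 h; on this read-out lower numbers stand for higher toxicity in this test and higher numbers for lower toxicity in this test.
Compound 2, `CCCCNc1nc2cc(-c3ccc(C)cc3)sc2c(=O)[nH]1`, gives 6000 nM in this assay.
Compound 3, `CC(C)(C)Nc1nc2cc(-c3ccc(Br)cc3)sc2c(=O)[nH]1`, gives 1400 nM in this assay.

The change hydrogen in place of methyl on a saturated chain carbon, three bonds along the chain from a nitrogen on an aromatic ring produced an at least 10-fold higher number from compound 2 to compound 1 (1.01 log units; beyond the scatter); this step is only a bound because the limit of > 62500 nM in this assay, at which 1 of the 3 values shown sits, holds compound 1 at the edge of the test. Compound 3 has the lowest number of the two measured, and the difference between its core and that of compound 2 is not broken down here. Compound 4, `CC(C)Nc1nc2cc(-c3ccc(Br)cc3)sc2c(=O)[nH]1`, differs from compound 3 by hydrogen in place of methyl on a saturated chain carbon bound to a nitrogen on an aromatic ring and two saturated chain carbons; this is the same kind of change as before, but here the carbon is bound to the ring nitrogen and two chain carbons rather than lying three bonds along the chain. On the step seen for compound 2 to compound 1, a rise is expected for compound 4, though a smaller one: a 2.5-fold higher number from compound 3 to compound 4 (0.40 log units; beyond the scatter) is estimated, giving 3500 nM (range 1200 nM to 12000 nM).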

Compound 4, half-maximal cytotoxic concentration: 13400 nM
For compound 4 the middle estimate is 3.8-fold (0.58 log units) below the measured one; measured number above the stated range.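

Taking a methyl away from the tert-butyl group to leave isopropyl gave a 9.6-fold higher number from compound 3 to compound 4 (0.98 log units; beyond the scatter) in this assay. The change therefore raised the number on both cores, and the two steps compare as follows: the same change on two cores in this assay, an at least 10-fold higher number (1.01 log units; beyond the scatter) from compound 2 to compound 1 and a 9.6-fold higher number (0.98 log units; beyond the scatter) from compound 3 to compound 4; the limit leaves it open whether they differ. This supports the same direction for the change in these two pairs, but it does not establish a fixed size for it or a rule for the whole series.

The compounds shown leave open whether an ethyl chain or a plain amine would continue this rise on either core. They also leave open how a propyl or butyl chain would behave on the core of compound 3.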